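The compounds below may be only part of what the source reports. "The series", "measured", "known", "first", "only" and "open" are said of these compounds alone.

Measured in a functional assay on MCF7 cells (Homo sapiens) for antiproliferative activity, read by MTT assay, with a stated time of 48 h; a higher number here means a weaker inhibitor, a lower number a stronger inhibitor:
- compound 1 `CC[C@@H](C)[C@H](NC(=O)c1ccc(Oc2nc3ccccc3nc2C)cc1)C(=O)OC`: 36100 nM
- compound 2 `CC[C@@H](C)[C@H](NC(=O)c1ccc(Oc2nc3ccccc3nc2NC(C)(C)C)cc1)C(=O)OC`: 33400 nM

Compound 2 stands level with compound 1 on these numbers, as the two values lie within the scatter of each other. The next compound is compound 3 `CC[C@@H](C)[C@H](NC(=O)c1ccc(Oc2nc3ccccc3nc2NC(C)(C)C)cc1)C(=O)O`. The change is hydrogen in place of methyl on an oxygen next to a carbonyl group, or methoxycarbonyl to carboxy.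

Among the measured compounds shown here, only one measured step is available, a 1.1-fold lower number from compound 1 to compound 2 (0.03 log units; within the scatter). It comes from (tert-butyl)amino in place of methyl on an aromatic carbon and stays within the scatter. That step bears on the new change only indirectly, since it leaves the methoxycarbonyl group untouched. For the measured compounds named here, no measured compound carries a carboxy group, so the data give no direction for this change. No step beyond the scatter is therefore expected in this assay, though the range must stay wide. The expected step is a 1.1-fold higher number from compound 2 to compound 3 (0.03 log units; within the scatter). Compound 3 is estimated at 36000 nM, with an expected range of 14000 nM to 90000 nM.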

Compound 3, half-maximal inhibitory concentration: 11400 nM
Compound 3: the middle estimate sits 3.2-fold (0.50 log units) above what was measured; measured number outside the range, below it.
By their numbers in this assay, from the lowest: compound 3; then compounds 2 and 1 (each within the scatter of the next).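

Hydrogen in place of methyl on an oxygen next to a carbonyl group, or methoxycarbonyl to carboxy, gives the first step in the series to lie beyond the scatter in this assay: a 2.9-fold lower number from compound 2 to compound 3 (0.47 log units; beyond the scatter). The earlier exchange of methyl for (tert-butyl)amino on an aromatic carbon moved nothing beyond the scatter, so this position is the only one shown so far where a single change shifts the number, although the shift is modest and compound 3 still reads 11400 nM. Nothing in the material at hand accounts for the step.

The compounds shown leave open whether methoxycarbonyl to carboxy gives a similar step with methyl in place of (tert-butyl)amino on the aromatic carbon, since the step is read on the (tert-butyl)amino compounds alone. They also leave open whether the step needs the carboxy group itself or follows from losing the methoxy group, which a primary amide, an ethyl ester or a hydroxymethyl group at the same position would help to separate.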